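The source may hold more compounds than are shown below. What is called first, only, known or untested is meant among the compounds shown, and "the series" means these compounds.

Compound 1 `CN(C)c1cc2[nH]c(C3CCCCC3)nc2cc1NC(=O)OCc1ccccc1`: > 100 ug/mL
Compound 2 `CN(C)c1cc2[nH]c(C3CCCCC3)nc2cc1NC(=O)c1cccc(Br)c1`: > 100 ug/mL

In an ADME assay on Vero cells (Chlorocebus sabaeus) for cytotoxicity, read by resazurin assay, with a stated time of 3 days (on this read-out higher numbers stand for weaker inhibition and lower numbers for stronger inhibition), compound 1 gives > 100 ug/mL, which is a limit of the assay rather than a number. In this assay compound 2 likewise gives > 100 ug/mL, again a limit. For the measured compounds named here, compound 2 thus stands where every value so far stands (the limit of > 100 ug/mL in this assay, at which 2 of the 2 values shown sit). Going by the values given here, the single measured step, a step that the two limits leave unreadable from compound 1 to compound 2, shows only that both of its ends rest at that limit and gives no readable size.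

Compound 3 `CN(C)c1cc2[nH]c(C3CCCCC3)nc2cc1NC(=O)c1ccc(F)cc1` is not yet measured. It differs from compound 2 by 4-fluorophenyl in place of 3-bromophenyl on a carbonyl carbon. Among the compounds with values here, no measured step changes the group on the carbonyl carbon in this way, so no direction can be read from the numbers. Within the data shown here, the expectation for compound 3 is no step beyond the scatter, a number no higher from compound 2 to compound 3 (the limit leaves the size open), because both values so far rest at the limit (the limit of > 100 ug/mL in this assay, at which 2 of the 2 values shown sit). Compound 3 is therefore estimated at 100 ug/mL, within a range from 50 ug/mL to 200 ug/mL, most likely reported again as a limit.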

Compound 3, half-maximal inhibitory concentration: > 100 ug/mL
Compound 3: only a limit was reported; the forecaster's own chance of this, stated with the estimate: 85%; the middle value lies on the limit itself.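

Compound 3 rests with compound 1 and compound 2 at a limit rather than a number, so no step among these three compounds can be read: the limit of > 100 ug/mL in this assay, at which 3 of the 3 values shown sit.

The compounds shown leave open what concentration, if any, would bring each of them to half-maximal inhibition, and whether changing the group on the carbonyl carbon alters it.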